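The compounds below may be only part of what the source reports. "The series", "measured", "known", "first", "only" and "open" are said of these compounds alone.

Measured so far in an assay on CHO cells for displacement of a labelled ligand from adenosine receptor A3 (Homo sapiens), read by scintillation counting, tested at 10 uM; on this read-out higher numbers stand for more inhibition at the one concentration tested (going by the name of the read-out) and lower numbers for less inhibition:
compound 1 `Cc1csc(N)c1C(=O)c1ccc(Cl)cc1` gives 1%
compound 2 `CC(C)(C)Cc1csc(N)c1C(=O)c1ccc(Cl)cc1` gives 5%
compound 3 `Cc1ccc(C(=O)c2c(CC(C)(C)C)csc2N)cc1` gives 1%

All three figures sit close to the floor of this assay. Compound 2 carries the largest of the three numbers, but a number 4 percentage points higher from compound 1 to compound 2 (within the scatter) and a number 4 percentage points lower from compound 2 to compound 3 (within the scatter) both fall within the scatter, so compound 2 is not separated from either neighbour and no ordering can be read from the series.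

Compound 4 `CC(C)(C)Cc1c(-c2cn[nH]c2)sc(N)c1C(=O)c1ccc(Cl)cc1` is not yet measured. Relative to compound 2 the change is 1H-pyrazol-4-yl in place of hydrogen on an aromatic carbon.

Neither measured step bears directly on this change. The step from compound 1 to compound 2 altered the saturated chain on the five-membered ring, the step from compound 2 to compound 3 altered the substituent on the six-membered ring, and both stayed within the scatter. Among the compounds with values here, there is no precedent for placing an aromatic ring on the five-membered ring itself, so the expectation rests only on the flat behaviour of the series so far.

Expected for compound 4: no step beyond the scatter, a number 3 percentage points higher from compound 2 to compound 4 (within the scatter), with a wider range than the measured steps would suggest because the change is larger than any already tried. Estimated value for compound 4: 8%, range 0% to 30%.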

Compound 4, a percentage reported as inhibition, at one concentration (the size of the read-out at that concentration, not a potency): 1%
The estimate for compound 4 lay 7 percentage points above the measured number, and the stated range covers the measured number.
By their numbers in this assay, from the lowest: compounds 1, 3, 4 and 2 (each within the scatter of the next).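

Up to compound 4, the aromatic carbon next to the ring sulfur and next to the ring atom that bears a neopentyl group carried only hydrogen in the compounds shown. In this assay, placing 1H-pyrazol-4-yl there, with its 5 heavy atoms, 1 hydrogen-bond donor and 1 hydrogen-bond acceptor, gives a number 4 percentage points lower from compound 2 to compound 4 (within the scatter) and so shows that a whole aromatic ring on this carbon leaves the read-out near the floor, with no inhibition that can be told apart from that of compound 2. No measurement at hand accounts for this flat result or assigns any property to the new group.

With all the numbers near the floor, this position has no reading in either direction yet, and a group that lifts inhibition clear of the scatter remains to be found. Still open, from the compounds shown here alone, is whether a phenyl ring, a carboxylic acid or an amine on this same carbon, or a longer chain in place of the neopentyl group, would separate from compound 2 on this read-out.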